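Working notes: carbonyl removal at the acetyl of compound 1

The source may report more compounds than this note shows. Statements on the series, on what has been measured and on what is new or still open speak of the compounds shown alone.

Measured so far in an assay on isolated protein for inhibition of ubiquitin carboxyl-terminal hydrolase 7 (Homo sapiens), read by fluorescence, with stated times of 30 min and 3 h; a lower number here means a stronger inhibitor, a higher number a weaker inhibitor:
compound 1 `CC(=O)c1nc([N+](=O)[O-])c(Sc2c(Cl)cncc2Cl)s1`: 670 nM
compound 2 `O=C(Nc1ccccc1)c1nc([N+](=O)[O-])c(Sc2c(Cl)cncc2Cl)s1`: 40500 nM
compound 3 `O=C(NCc1ccc(F)cc1)c1nc([N+](=O)[O-])c(Sc2c(Cl)cncc2Cl)s1`: 2650 nM

Compound 1 gives the lowest of the three numbers in this assay; its nearest neighbour is compound 3 and its furthest is compound 2, and both steps away from it lie beyond the scatter. Replacing the methyl on the carbonyl carbon by an anilino group gives a 60-fold higher number from compound 1 to compound 2 (1.78 log units; beyond the scatter), by a (4-fluorobenzyl)amino group a 4.0-fold higher number from compound 1 to compound 3 (0.60 log units; beyond the scatter); between the two amides, a 15-fold lower number from compound 2 to compound 3 (1.18 log units; beyond the scatter).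

Compound 4 `CC(O)c1nc([N+](=O)[O-])c(Sc2c(Cl)cncc2Cl)s1` is not yet measured. It differs from compound 1 in one place: 1-hydroxyethyl in place of acetyl on an aromatic carbon. Within the data shown here, none of the measured steps bears directly on this change: all three keep the carbonyl and vary what sits beyond it, whereas compound 4 reduces the carbonyl itself while keeping the methyl. What the amides show is only that the acetyl region tolerates change poorly, every departure from compound 1 having given a higher number. On that basis a weakening is expected rather than a gain, but its size is uncertain.

For compound 4 the expected value in this assay is 2500 nM, with a range of 500 nM to 12000 nM, which would mean a 3.7-fold higher number from compound 1 to compound 4 (0.57 log units; beyond the scatter) as the estimated step.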

Compound 4, half-maximal inhibitory concentration: 6950 nM
Estimate against measurement, compound 4: 2.8-fold (0.44 log units) below; low and high end bracket the measured number.
By their numbers in this assay, from the lowest: compound 1; then compound 3; then compound 4; then compound 2.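

Reduction of the acetyl to 1-hydroxyethyl gives a 10-fold higher number from compound 1 to compound 4 (1.02 log units; beyond the scatter) in this assay and thus shows that the carbonyl itself counts at this position, not only what sits beyond it. The change leaves the methyl and the heavy-atom count as they were, removing the double bond outside aromatic rings and adding a hydrogen-bond donor. This alteration is confined to the carbon on the ring, whereas the amides changed the group beyond the carbonyl. Compound 1 keeps the lowest number of the four, each of the three departures at this place lying above it, and no measurement to hand accounts for the size of the new step.

The compounds shown do not separate the loss of the carbonyl from the gain of the hydrogen-bond donor; 1-methoxyethyl and plain ethyl on the same ring carbon would bear on that directly. Also open, going by these compounds, is how the position responds to a longer ketone such as propanoyl, or to a carboxylic acid in place of the acetyl.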